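Notes on the step from compound 2 to compound 4

The source may hold more compounds than are shown below. What is called first, only, known or untested is meant among the compounds shown, and "the series" means these compounds.

Measured so far:
- compound 1 `CN1CCN(C(=O)/C=C/c2cccc(C(F)(F)F)c2)CC1` gives > 75 mg/kg
- compound 2 `CN1C(=O)CCC1(O)c1cccc(C(F)(F)F)c1` gives 51.6 mg/kg
- compound 3 `CN1C(=O)CCC1(O)c1ccc(C(F)(F)F)cc1` gives 132 mg/kg

These values come from a functional assay on the whole organism with Mus musculus as the target (on this read-out higher numbers stand for an effect only at larger amounts of compound and lower numbers for an effect already at smaller amounts), as the read-out. For compound 1 the entry (> 75 mg/kg) is a limit of the assay and not a number. Compound 2 holds the lower of the two actual numbers (51.6 mg/kg). Compound 3 gives 132 mg/kg. It is the nearest neighbour of compound 2 and lies higher, and the gap between the two lies beyond the scatter.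

The next compound is compound 4 `CCCN1C(=O)CCC1(O)c1cccc(C(F)(F)F)c1`, which carries ethyl in place of hydrogen on a saturated chain carbon bound to an amide-type nitrogen in a ring. The same difference reads as methyl to propyl. Going by the values given here, no measured pair shows this change, so the expectation has little to rest on. In this assay no step beyond the scatter is expected, with a slight lean towards a higher number. The expected size is a 1.2-fold higher number from compound 2 to compound 4 (0.07 log units; within the scatter) as an estimate. For compound 4 the estimated value is 60 mg/kg, with an expected range from 25 mg/kg to 140 mg/kg as the outer ends.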

Compound 4, dose for half-maximal effect: 150 mg/kg
Beside the measured number, compound 4's estimate is 2.5-fold (0.40 log units) below it; measured number outside the range, above it.
By their numbers in this assay, from the lowest: compound 2; then compounds 3 and 4 (each within the scatter of the next).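

In this assay, the place on a saturated chain carbon bound to an amide-type nitrogen in a ring gets its first reading from a matched pair: ethyl in place of hydrogen gives a 2.9-fold higher number from compound 2 to compound 4 (0.46 log units; beyond the scatter). The earlier compounds shown here showed no step at this place, and this one shows that the place is not indifferent to the change, with compound 2 keeping the lower number of the pair and the rest of the core unchanged. Nothing shown here accounts for the size or direction of this step.

A single step cannot tell whether a longer chain such as butyl, or a chain carrying an amine, would continue in the same direction at this place. It also leaves open whether the same change made on compound 3 would give a step of similar size.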